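Chloro Enters a Weakly Inhibiting Series

This account rests on a few compounds, and the source may have more. Where it says the series, first, only, none or still open, it means among the compounds named here.

In a functional assay on A549 cells (Homo sapiens) for inhibition, read by sulforhodamine B assay, with a stated time of 48 h (a lower number here means a stronger inhibitor, a higher number a weaker inhibitor), compound 1 `Cc1ccc2occ(C3N=C(c4ccccc4)SS3)c(=O)c2c1` gives 66500 nM, and compound 2 `O=c1c(C2N=C(c3ccccc3)SS2)coc2ccc(F)cc12` gives 91100 nM. Compound 3 `O=c1c(C2N=C(c3ccccc3)SS2)coc2ccccc12` reaches only the assay limit in this assay, > 100000 nM. Compound 2 stands highest of the two numbers given, though the margin a 1.4-fold higher number from compound 1 to compound 2 (0.14 log units; within the scatter). Compound 4 `O=c1c(C2N=C(c3ccccc3)SS2)coc2cc(Cl)c(F)cc12` differs from compound 2 by chloro in place of hydrogen on an aromatic carbon. The measured steps that bear on this change, a 1.4-fold higher number from compound 1 to compound 2 (0.14 log units; within the scatter), an at least 1.0-fold higher number from compound 2 to compound 3 (0.04 log units; that floor lies within the scatter) and an at least 1.5-fold higher number from compound 1 to compound 3 (0.17 log units; that floor lies within the scatter), all lie within the scatter, and two of them end at a limit (the limit of > 100000 nM in this assay, at which 1 of the 3 values shown sits). One therefore expects from compound 2 to compound 4 no step beyond the scatter, a 1.1-fold lower number from compound 2 to compound 4 (0.06 log units; within the scatter). Compound 4 is estimated at 80000 nM, between 30000 nM and 200000 nM.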

Compound 4, half-maximal inhibitory concentration: 93500 nM
For compound 4 the middle estimate is 1.2-fold (0.07 log units) below the measured one; the range from low to high includes it.
By their numbers in this assay, from the lowest: compounds 1, 2 and 4 (each within the scatter of the next). At a limit, above all of these: compound 3.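

In this assay, chloro in place of hydrogen on the aromatic carbon ortho to the fluoro group gives a 1.0-fold higher number from compound 2 to compound 4 (0.01 log units; within the scatter). Within the data shown here, this position thus takes a chlorine atom with no step beyond the scatter, which the earlier compounds could not show, since their steps concerned only methyl, fluoro and hydrogen at another aromatic carbon. Compound 3 remains a limit and not a number: the limit of > 100000 nM in this assay, at which 1 of the 4 values shown sits.

From the compounds shown here alone, whether an amine or a carboxylic acid at this position would move the number beyond the scatter stays open, as does how chloro behaves there without the fluoro group.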